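Long-chain polyynol series: one group shortened

The source may hold more compounds than are shown below. What is called first, only, known or untested is meant among the compounds shown, and "the series" means these compounds.

- compound 1 `C#C/C=C\CCCCCCCCCCCCCCC/C=C\CCCC/C=C\CCCCC#C[C@@H](O)C#CCCCCCC/C=C/[C@H](O)C#C`: 1.7 ug/mL
- compound 2 `C#C/C=C\CCCCCCCCCCCCC/C=C/C(=O)CCCC/C=C\CCCCC#C[C@@H](O)C#CCCCCCC/C=C/[C@H](O)C#C`: 5.7 ug/mL

In a functional assay on HCT-15 cells (Homo sapiens) for cytotoxicity (a lower number here means that less compound is needed, a higher number that more compound is needed for the effect), compound 1 has the lower of the two numbers, and the higher number of compound 2 lies beyond the scatter. Less of compound 1 is therefore needed for the effect. Going by the values given here, these two compounds differ in more than one place, so no measured step isolates a single change.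

Compound 3 `C#C/C=C\CCCCCCCCCCCCCC/C=C\CCCC/C=C\CCCCC#C[C@@H](O)C#CCCCCCC/C=C/[C@H](O)C#C` has not yet been measured. It departs from compound 1 as follows: a group of 4 heavy atoms (4 carbon; no ring) in place of a group of 5 heavy atoms (5 carbon; no ring), on a saturated chain carbon, ten or more bonds along the chain from a double-bonded chain carbon.

Among the compounds with values here, with no measured step as a guide, no shift beyond the scatter is expected in this assay, and no direction is favoured. The expected result is a 1.2-fold higher number from compound 1 to compound 3 (0.07 log units; within the scatter). For compound 3 the estimate is 2 ug/mL, with an expected range of 1 ug/mL to 4.5 ug/mL.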

Compound 3, concentration for half-maximal effect: 2.5 ug/mL
The estimate for compound 3 lay 1.3-fold (0.10 log units) below the measured number, within the range that was stated.
By their numbers in this assay, from the lowest: compounds 1 and 3 (each within the scatter of the next); then compound 2.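

In this assay the change at this saturated chain carbon gives a 1.5-fold higher number from compound 1 to compound 3 (0.17 log units; within the scatter) and so shows no resolved shift when the group of 4 heavy atoms takes the place of the group of 5 heavy atoms. This is the only step shown that isolates a single change, which compound 2 could not provide, as it differs from compound 1 in more than one place. No measurement on hand offers an explanation for this result.

As far as these compounds go, whether a longer chain, an amine or a carboxylic acid in this place would also leave the number in this assay within the scatter remains open. Also open, from the compounds shown here alone, is which of the several differences between compound 1 and compound 2 goes with the higher number of compound 2.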